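A few compounds are considered here, and "the series" means these few. Any claim that something is new, unique, unknown or untested is made for them only; others in the source may bear on it.

Two acylguanidines built on a shared aminothiazole core were examined in a functional assay on Right cardiac atrium for agonist activity at histamine H2 receptor (Cavia porcellus), with a stated time of 30 min, in the presence of a further agent that is not named here; on this read-out higher numbers stand for larger maximal responses and lower numbers for smaller maximal responses. Compound 1 `COc1ccc(C(C)NC(=O)/N=C(\N)NCCCc2sc(N)nc2C)cc1` carries a 1-(4-methoxyphenyl)ethyl group on the amide-type nitrogen, and in this assay compound 1 gives 0.91. Compound 2 `CCCCCNC(=O)/N=C(\N)NCCCc1sc(N)nc1C` carries a pentyl group in the same place, and in this assay compound 2 gives 0.78. Of the two numbers measured, compound 2 stands lowest, and the gap between it and compound 1 lies beyond the usual scatter of the read-out.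

Compound 3 `Cc1nc(N)sc1CCCN/C(N)=N/C(=O)NC(C)c1ccco1` has not yet been measured. It differs from compound 2 in one place: 1-(furan-2-yl)ethyl in place of pentyl on an amide-type nitrogen. Since compound 1 shows that an aromatic ring on a one-carbon-branched group at this nitrogen goes with a higher maximal response, the expectation is that the move to compound 3 raises the read-out, though by a modest amount. The step estimated for this change in this assay is a number 0.10 higher from compound 2 to compound 3 (within the scatter), upward. Compound 3 is therefore expected to give about 0.88 in this assay, within a range from 0.75 to 1.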

Compound 3, intrinsic activity: the largest response reached, as a fraction of the reference agonist's: 1
The estimate for compound 3 lay 0.12 below the measured number; the range from low to high includes it.
By their numbers in this assay, from the lowest: compound 2; then compounds 1 and 3 (each within the scatter of the next).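

In this assay, the change on the amide-type nitrogen from pentyl to 1-(furan-2-yl)ethyl amounts to a number 0.22 higher from compound 2 to compound 3 (beyond the scatter), showing that this position can separate these two groups by more than the usual variation between repeats. The aromatic ring at this position also tolerates a change of identity, since furan-2-yl in place of 4-methoxyphenyl on the saturated chain carbon gives a number 0.090 higher from compound 1 to compound 3 (within the scatter), so the read-out does not distinguish between these two ring-bearing groups. No independent measurement is available to explain the difference between pentyl and 1-(furan-2-yl)ethyl.

The compounds shown leave open whether the furan ring or the branching carbon bearing its methyl group accounts for the step from pentyl, a question that a furan-2-ylmethyl group on the same nitrogen would address directly. They also leave open whether an aromatic ring is needed at all, as a cyclohexyl group on the same one-carbon branch would test, and how a carboxylic acid or an amine carried on that branch would fare in this read-out.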